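Terminal Hydroxyl Chain in Place of the Ethyl Ester

A few compounds are considered here, and "the series" means these few. Any claim that something is new, unique, unknown or untested is made for them only; others in the source may bear on it.

Compound 3 `CCOC(=O)CCCCCOc1ccc2c(=O)c(-c3ccc(O)cc3)coc2c1` gives 5300 nM in an assay (Cricetulus griseus) for inhibition of Monoamine oxidase (Homo sapiens) (a higher number here means a weaker inhibitor, a lower number a stronger inhibitor), and compound 2 `O=C(O)CCCCOc1ccc2c(=O)c(-c3ccc(O)cc3)coc2c1`, which gives 5000 nM, stands alongside it, since a 1.1-fold higher number from compound 2 to compound 3 (0.03 log units; within the scatter). For compound 1 `NCCCCCCOc1ccc2c(=O)c(-c3ccc(O)cc3)coc2c1` this assay reports only a limit of >> 9000 nM, as noted in the limit of >> 9000 nM in this assay, at which 1 of the 3 values shown sits. Compound 4 `O=c1c(-c2ccc(O)cc2)coc2cc(OCCCCCCCCCO)ccc12` differs from compound 3 by 4-hydroxybutyl in place of ethoxycarbonyl on a saturated chain carbon, five bonds along the chain from an oxygen on an aromatic ring. Going by the values given here, the steps that bear on this change are an at least 1.6-fold lower number from compound 1 to compound 3 (0.22 log units; that floor lies within the scatter) and an at least 1.8-fold lower number from compound 1 to compound 2 (0.25 log units; that floor lies within the scatter), both of which are floors set by a limit, together with a 1.1-fold higher number from compound 2 to compound 3 (0.03 log units; within the scatter). None of the changes at the chain end so far shifted the number beyond the scatter, so a step of a 1.1-fold higher number from compound 3 to compound 4 (0.05 log units; within the scatter) is expected, with no clear direction. Compound 4 is therefore estimated at 6000 nM, between 2500 nM and 15000 nM.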

Compound 4, half-maximal inhibitory concentration: > 9000 nM
Compound 4: a limit, no number; the forecaster's own chance of this, stated with the estimate: 25%; middle value at least 1.5-fold (0.17 log units) from the limit.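

Compound 4 gives only a limit in this assay, > 9000 nM. Placing 4-hydroxybutyl on the chain gives an at least 1.6-fold higher number from compound 3 to compound 4 (0.22 log units; that floor lies within the scatter) and an at least 1.8-fold higher number from compound 2 to compound 4 (0.25 log units; that floor lies within the scatter), so neither floor shows a change beyond the scatter. The step involving compound 1 cannot be read, but among these compounds, only the chains ending in carboxy or ethoxycarbonyl give numbers, while those ending in hydroxyl or amino give limits.

On these data alone, it remains open whether the hydroxyl end or the longer saturated chain matters. A shorter chain ending in hydroxyl, or a longer chain ending in a carboxylic acid, would separate the two.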